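Swapping the Amide Side Chain of Compound 1

This account rests on a few compounds, and the source may have more. Where it says the series, first, only, none or still open, it means among the compounds named here.

In an in vitro ADME assay on microsomes from liver (Homo sapiens) for metabolic stability, in the presence of a further agent that is not named here (a higher number here means faster removal of the compound, a lower number slower removal), compound 1 `CC(C)(CO)CNC(=O)c1cc2cc(C#N)ccc2n1Cc1cccc(OC(F)(F)F)c1` gives 20 mL.min-1.g-1. Two relatives were measured alongside it: compound 2 `COc1ccc(OC(F)(F)F)cc1Cn1c(C(=O)NCC(C)(C)CO)cc2cc(C#N)ccc21` gives 31 mL.min-1.g-1, and compound 3 `CCCOc1cccc(Cn2c(C(=O)NCC(C)(C)CO)cc3cc(C#N)ccc32)c1` gives 10 mL.min-1.g-1. The number for compound 1 is the second highest of the three, although the steps to both relatives stay within the scatter.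

The next compound to be measured is compound 4 `N#Cc1ccc2c(c1)cc(C(=O)NCCC(O)(C(F)(F)F)C(F)(F)F)n2Cc1cccc(OC(F)(F)F)c1`, which keeps the core of compound 1 and changes only the amide side chain: 3,3,3-trifluoro-2-hydroxy-2-(trifluoromethyl)propyl in place of 1-(hydroxymethyl)-1-methylethyl on a saturated chain carbon bound to an amide-type nitrogen. Going by the values given here, no measured step involves this chain. The two available steps come from elsewhere in the structure. Methoxy in place of hydrogen on an aromatic carbon gives a 1.6-fold higher number from compound 1 to compound 2 (0.19 log units; within the scatter), and propyl in place of trifluoromethyl on an oxygen on an aromatic ring gives a 2.0-fold lower number from compound 1 to compound 3 (0.30 log units; within the scatter). They therefore offer no direction for the new change and show only that this assay has so far moved little across this small set. With so little evidence, no shift beyond the scatter is expected, though the uncertainty is wide. The expected change is a 1.1-fold lower number from compound 1 to compound 4 (0.05 log units; within the scatter). Compound 4 is estimated at 18 mL.min-1.g-1, with the measurement expected to fall between 7 mL.min-1.g-1 and 45 mL.min-1.g-1.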

Compound 4, intrinsic clearance in microsomes: 24 mL.min-1.g-1
For compound 4 the middle estimate is 1.3-fold (0.12 log units) below the measured one; the range from low to high includes it.
By their numbers in this assay, from the lowest: compounds 3, 1, 4 and 2 (each within the scatter of the next, the first and the last beyond it).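

In this assay, the change at this place, on a saturated chain carbon bound to an amide-type nitrogen, gives a 1.2-fold higher number from compound 1 to compound 4 (0.08 log units; within the scatter), and it is the first step shown that touches the amide side chain rather than the other end of the molecule. The entering 3,3,3-trifluoro-2-hydroxy-2-(trifluoromethyl)propyl chain holds 11 heavy atoms, 6 of them fluorine, against 5 heavy atoms in 1-(hydroxymethyl)-1-methylethyl, with the same count of hydrogen-bond donors and acceptors, so this much heavier chain does not separate compound 4 from compound 1 in this read-out. Nothing available explains this outcome.

From the compounds shown here alone, with a single step at this place, it remains open whether a side chain ending in an amine or a carboxylic acid, or a longer chain, would move the number beyond the scatter. Going by these compounds, it is also open whether the same chain would give a similar step on compound 2 or compound 3, whose other substituents might change how it reads.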